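The source may hold more compounds than are shown below. What is called first, only, known or untested is meant among the compounds shown, and "the series" means these compounds.

Two compounds in the series carry measured values. Compound 1 `O=C(O)c1nn(Cc2cc(Br)ccc2OCc2ccccc2)cc1CO` in a functional assay on CHO-K1 cells for antagonist activity at prostaglandin E2 receptor EP1 subtype (Homo sapiens), read by FLIPR (on this read-out higher numbers stand for weaker inhibition and lower numbers for stronger inhibition), gives < 2000 nM, which is a limit of the assay and not a number. Compound 1 thus sits at the limit of < 2000 nM in this assay, at which 1 of the 2 values shown sits, and nothing beyond that limit is known of it. Within the data shown here, compound 2 `Cc1cc(C(=O)O)nn1Cc1cc(Br)ccc1OCc1ccc(F)cc1F` in this assay gives 2.63 nM, the only full number in the set, so its standing rests on that single value. Compound 3 `Cc1cc(C(=O)O)nn1Cc1cc(Br)ccc1OCc1cccc(Cl)c1` is not yet measured. It differs from compound 2 by 3-chlorophenyl in place of 2,4-difluorophenyl on a saturated chain carbon bound to an oxygen on an aromatic ring. Among the measured compounds shown here, no step between two measured compounds runs through this part of the structure, so the present data give no measured size for such a change. The expectation for compound 3 in this assay is a modest loss, the step estimated as a 2.3-fold higher number from compound 2 to compound 3 (0.36 log units; beyond the scatter), which may still fall within the scatter. Compound 3 is estimated at 6 nM, with a range from 1.5 nM to 25 nM.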

Compound 3, inhibition constant: 427 nM
Beside the measured number, compound 3's estimate is 71-fold (1.85 log units) below it, outside the stated range (above it).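

In this assay this position proves far from indifferent: 3-chlorophenyl in place of 2,4-difluorophenyl on a saturated chain carbon bound to an oxygen on an aromatic ring gives a 160-fold higher number from compound 2 to compound 3 (2.21 log units; beyond the scatter) with the rest of the structure unchanged. Among these compounds, this is the first measured size for any change, and it shows that the nanomolar inhibition of compound 2 depends strongly on the halogen pattern of this ring. Among the compounds shown here, nothing measured so far bears on why the step is so large.

A single step cannot separate the identity of the halogen from its placement on the ring, and a 2,4-dichlorophenyl group on the same chain carbon would help to divide the two. Going by these compounds, whether a ring carrying a methoxy group or a nitrile would hold the inhibition of compound 2 also stays open.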